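Working notes: butoxy in place of chloro on compound 3

The source may report more compounds than this note shows. Statements on the series, on what has been measured and on what is new or still open speak of the compounds shown alone.

Values in a functional assay on MCF7 cells (Homo sapiens) for antiproliferative activity, read by sulforhodamine B assay, with a stated time of 48 h (on this read-out lower numbers stand for stronger inhibition and higher numbers for weaker inhibition), for the measured compounds:
- Compound 1 `O=C1NCCN1c1ccc(S(=O)(=O)Nc2ccc(F)cc2)cc1` gives 690 nM
- Compound 2 `CCCCCCCc1ccc(NS(=O)(=O)c2ccc(N3CCNC3=O)cc2)cc1` gives > 1000 nM (a limit of the assay, not a number)
- Compound 3 `O=C1NCCN1c1ccc(S(=O)(=O)Nc2ccc(Cl)cc2)cc1` gives 170 nM

Compound 3 stands lowest of the values shown. Within the data shown here, the only other true number belongs to compound 1, and the step between them is a 4.1-fold lower number from compound 1 to compound 3 (0.61 log units; beyond the scatter). Compound 2 reports a limit and not a number.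

The change leading to compound 4 `CCCCOc1ccc(NS(=O)(=O)c2ccc(N3CCNC3=O)cc2)cc1` is butoxy in place of chloro on an aromatic carbon, para to a large group (butoxy in place of chloro on an aromatic carbon).

The nearest guide is an at least 5.8-fold lower number from compound 2 to compound 3 (0.76 log units; beyond the scatter), where chloro replaces heptyl. The change here runs the other way, from chloro back to a chain. That step is only a floor, set by a limit. The step of an at least 1.4-fold higher number from compound 1 to compound 2 (0.16 log units; that floor lies within the scatter) adds little, while a 4.1-fold lower number from compound 1 to compound 3 (0.61 log units; beyond the scatter) shows that swapping one group for another can move the number beyond the scatter. Among the measured compounds shown here, no butoxy compound has been measured, and butoxy and heptyl are different groups, so the size remains uncertain. A higher number of modest size is expected in this assay.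

The expected step is a 2.9-fold higher number from compound 3 to compound 4 (0.47 log units; beyond the scatter).

For compound 4 the estimate is 500 nM, with an expected range from 150 nM to 1600 nM.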

Compound 4, half-maximal inhibitory concentration: 870 nM
Compound 4: middle estimate off by 1.7-fold (0.24 log units), on the low side; measured number inside the range.
By their numbers in this assay, from the lowest: compound 3; then compounds 1 and 4 (each within the scatter of the next). At a limit, above all of these: compound 2.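

In this assay, among these compounds, butoxy gives the first true number for a chain at this position, where the change from chloro had until now been known only as a floor set by a limit: a 5.1-fold higher number from compound 3 to compound 4 (0.71 log units; beyond the scatter). The step from fluoro to butoxy at this position is a 1.3-fold higher number from compound 1 to compound 4 (0.10 log units; within the scatter), so these two groups do not separate. Among the three groups with true numbers only chloro stands apart, and the series offers no sign that a chain here improves on it. Compound 2 reports a limit and not a number. The step from heptyl to butoxy is only a floor, an at least 1.1-fold lower number from compound 2 to compound 4 (0.06 log units; that floor lies within the scatter), which leaves heptyl and butoxy unordered: the limit of > 1000 nM in this assay, at which 1 of the 4 values shown sits.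

The compounds shown leave open whether bromo, methyl or methoxy at this position would keep the number close to that of compound 3, and whether the oxygen of butoxy or the length of its chain goes with the higher number. They also leave open how an amine or a carboxylic acid would behave here, and whether the order of these groups would hold on any core other than the shared one.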